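Amide heteroaryl swap and tolerance on Vero cells

This account rests on a few compounds, and the source may have more. Where it says the series, first, only, none or still open, it means among the compounds named here.

Of the compounds shown here, two sharing one core have been tested in an ADME assay on Vero cells (Chlorocebus sabaeus) for cytotoxicity; a lower number here means that less compound is tolerated, a higher number that more compound is tolerated. Compound 1 `COc1ccc(-c2nc3c(C(=O)Nc4c[nH]cn4)cccc3[nH]2)cc1OC` gives 306 uM in this assay, the higher of the two numbers. Among the measured compounds shown here, compound 2 `COc1ccc(-c2nc3c(C(=O)Nc4cnccn4)cccc3[nH]2)cc1OC` gives 98.8 uM, the lowest of the two numbers; its only neighbour is compound 1, and the move between them, a 3.1-fold lower number from compound 1 to compound 2 (0.49 log units; beyond the scatter), is the single measured step that bears on the present question.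

Compound 3 `COc1ccc(-c2nc3c(C(=O)Nc4nc5ccccc5[nH]4)cccc3[nH]2)cc1OC` is not yet measured. It differs from compound 2 in one place: 1H-benzimidazol-2-yl in place of pyrazin-2-yl on an amide-type nitrogen. For the measured compounds named here, since the one known step in this assay shows that exchanging the heteroaryl on the amide nitrogen can shift the number by a modest amount, and since a donor returns with the entering group as it was present in compound 1, the expectation is a step of a 1.4-fold lower number from compound 2 to compound 3 (0.15 log units; within the scatter), with the direction uncertain and possibly within the scatter. The estimate for compound 3 in this assay is 70 uM, with a range from 20 uM to 250 uM.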

Compound 3, half-maximal toxic concentration: 51.8 uM
Compound 3: middle estimate off by 1.4-fold (0.13 log units), on the high side; the measured number falls inside the stated range.
By their numbers in this assay, from the lowest: compounds 3 and 2 (each within the scatter of the next); then compound 1.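

In this assay, putting 1H-benzimidazol-2-yl in place of pyrazin-2-yl on the amide-type nitrogen gives a 1.9-fold lower number from compound 2 to compound 3 (0.28 log units; within the scatter), so a larger group with a fused carbon-only ring can enter here without a step that stands clear of the scatter. The comparison with the other neighbour is clearer, at a 5.9-fold lower number from compound 1 to compound 3 (0.77 log units; beyond the scatter): the hydrogen-bond donor that enters with 1H-benzimidazol-2-yl does not bring the number back to that of compound 1, and among these three compounds, 1H-imidazol-4-yl alone stands beyond the scatter from both other groups. Nothing available explains why these groups differ in this way.

The compounds shown leave open whether a plain phenyl, or a ring carrying an amine or a carboxylic acid, on this amide-type nitrogen would fall with compound 1 or with compound 2 and compound 3. They also leave open whether 1H-imidazol-4-yl would keep its separation from pyrazin-2-yl and 1H-benzimidazol-2-yl on any core other than the shared one.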